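Methoxycarbonyl in place of trifluoromethoxy on a shared core

The source may hold more compounds than are shown below. What is called first, only, known or untested is meant among the compounds shown, and "the series" means these compounds.

In a physicochemical assay for solubility, read by spectrophotometry, in phosphate buffer, with a stated time of 18 h, at pH 7.4 (on this read-out higher numbers stand for higher solubility and lower numbers for lower solubility), compound 1 (`CCc1ccc(-c2nc3c(c(C)nn3-c3ccccc3)c(-c3ccccc3C)c2C#N)cc1`) gives 6000 nM, compound 2 (`CCc1ccc(-c2nc3c(c(C)nn3-c3ccccc3)c(-c3ccccc3C(=O)O)c2C#N)cc1`) gives 33000 nM and compound 3 (`CCc1ccc(-c2nc3c(c(C)nn3-c3ccccc3)c(-c3ccccc3OC(F)(F)F)c2C#N)cc1`) gives 9900 nM. Compound 3 therefore stands with compound 1 and apart from compound 2. The data show a 1.7-fold higher number from compound 1 to compound 3 (0.22 log units; within the scatter), a step within the scatter, and a 3.3-fold lower number from compound 2 to compound 3 (0.52 log units; beyond the scatter), a modest step beyond it.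

Compound 4 (`CCc1ccc(-c2nc3c(c(C)nn3-c3ccccc3)c(-c3ccccc3C(=O)OC)c2C#N)cc1`) carries methoxycarbonyl in place of trifluoromethoxy on an aromatic carbon, ortho to a large group: methoxycarbonyl in place of trifluoromethoxy on an aromatic carbon. Among the measured compounds shown here, no measured compound carries methoxycarbonyl, so the comparison is indirect. The steps beyond the scatter, a 5.5-fold higher number from compound 1 to compound 2 (0.74 log units; beyond the scatter) and a 3.3-fold lower number from compound 2 to compound 3 (0.52 log units; beyond the scatter), both involve carboxy, which compound 4 lacks. For the measured compounds named here, the one step without carboxy, a 1.7-fold higher number from compound 1 to compound 3 (0.22 log units; within the scatter), stays within the scatter, so a step of that small size is the best available guide. The expected change in this assay is a 1.1-fold higher number from compound 3 to compound 4 (0.05 log units; within the scatter), with no step beyond the scatter in either direction. For compound 4 the estimated value is 11000 nM, with an expected range of 4500 nM to 26000 nM.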

Compound 4, solubility: 17000 nM
Beside the measured number, compound 4's estimate is 1.5-fold (0.19 log units) below it, within the range that was stated.
By their numbers in this assay, from the lowest: compounds 1, 3, 4 and 2 (each within the scatter of the next, the first and the last beyond it).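

In this assay the step of a 2.8-fold higher number from compound 1 to compound 4 (0.45 log units; beyond the scatter) shows that, on this aromatic carbon ortho to a large group, a step beyond the scatter from the methyl compound is not confined to carboxy. Methyl in place of hydrogen on the oxygen next to the carbonyl gives a 1.9-fold lower number from compound 2 to compound 4 (0.29 log units; within the scatter) and methoxycarbonyl in place of trifluoromethoxy gives a 1.7-fold higher number from compound 3 to compound 4 (0.23 log units; within the scatter) and both lie within the scatter, so compound 4 cannot be told apart from either compound, although the step between those two lies beyond it. Nothing among the data offered here accounts for any of these steps.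

The compounds shown leave open how an amide, an amine or a longer ester chain would read at this same place. They also leave open whether these steps would hold on a core other than the shared one.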